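Swapping a Nitrile for an Ester on the Side Chain

The source may hold more compounds than are shown below. What is called first, only, known or untested is meant among the compounds shown, and "the series" means these compounds.

Compound 1 `COCCOCn1cc[n+](C)c1/C=N/O` gives -2.81 in a physicochemical assay for lipophilicity; a higher number here means a more lipophilic compound, a lower number a more polar compound. Compound 3 `C[n+]1ccn(CCCCC#N)c1/C=N/O` gives -2.8 in this assay, and the step of a number 0.01 log units higher from compound 1 to compound 3 (within the scatter) lies within the scatter, so these two values stand together. Compound 2 `C[n+]1ccn(CCCC#N)c1/C=N/O` gives only a limit of the assay, < -3, in this assay. Compound 4 `COC(=O)CCCCCn1cc[n+](C)c1/C=N/O` is not yet measured. It differs from compound 3 by (methoxycarbonyl)methyl in place of cyano on a saturated chain carbon, four bonds along the chain from an aromatic nitrogen. The nearest measured step is a number at least 0.20 log units higher from compound 2 to compound 3 (that floor lies within the scatter), where a longer chain came with a value that climbed at least to the edge of the scatter, while the step of a number 0.01 log units higher from compound 1 to compound 3 (within the scatter) shows two different chains giving numbers within the scatter. On that basis a small upward step of a number 0.30 log units higher from compound 3 to compound 4 (within the scatter) is expected in this assay. Compound 4 is therefore estimated at -2.5, with a range from -2.9 to -2.1.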

Compound 4, distribution coefficient: -2.21
The estimate for compound 4 lay 0.29 log units below the measured number, and the stated range covers the measured number.
By their numbers in this assay, from the lowest: compounds 1 and 3 (each within the scatter of the next); then compound 4. At a limit, below all of these: compound 2.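

The ester chain moves the number in this assay as the earlier chains did not, with a number 0.59 log units higher from compound 3 to compound 4 (beyond the scatter) and a number at least 0.79 log units higher from compound 2 to compound 4 (beyond the scatter) as the two steps that show it. The second of these steps rests on a limit for compound 2, not on a number: the limit of < -3 in this assay, at which 1 of the 4 values shown sits.

The change from compound 3 to compound 4 alters both the end group and the size of the side chain, so the compounds shown do not tell these two apart. A nitrile on a longer chain, or a carboxylic acid in place of the ester, would help to separate them.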